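Replacing the aryl on the ring nitrogen of compound 2 with ethyl

This account rests on a few compounds, and the source may have more. Where it says the series, first, only, none or still open, it means among the compounds named here.

Measured so far:
compound 1, `COc1ccccc1N1C(=O)C(C)SC1c1cccc(C(=O)NCCCCc2ccccc2)c1`, 94%
compound 2, `COc1ccc(C)cc1N1C(=O)CSC1c1cccc(C(=O)NCCCCc2ccccc2)c1`, 92%
compound 3, `O=C(NCCCCc1ccccc1)c1cccc(C2OCC(=O)N2c2cccc(F)c2)c1`, 66%

In a functional assay on MG-63 cells (Homo sapiens) for inhibition, read by CCK-8 assay, with a stated time of 72 h, tested at 1 uM (a lower number here means less inhibition, a higher number more inhibition at the concentration tested (going by the name of the read-out)), compound 2 gives 92%. Of the three numbers it stands second highest. Its nearest neighbour is compound 1, which in this assay gives 94%, a figure within the scatter of compound 2, so the two cannot be told apart. Furthest away is compound 3, which in this assay gives 66%, well beyond the scatter and clearly lower than compound 2.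

Compound 4, `CCN1C(=O)CSC1c1cccc(C(=O)NCCCCc2ccccc2)c1`, has not yet been measured in this assay. It differs from compound 2 in one place: ethyl in place of 2-methoxy-5-methylphenyl on an amide-type nitrogen in a ring. The group that leaves carries one six-membered aromatic ring of carbon only and one hydrogen-bond acceptor; the ethyl that enters has no ring and no acceptor.

Going by the values given here, no pair of measured compounds differs in a single place, so no measured step can guide this change directly. Every measured compound keeps an aryl on the ring nitrogen, and all three show substantial inhibition. With wide uncertainty, the step is therefore estimated to be a number 32 percentage points lower from compound 2 to compound 4 (beyond the scatter). For compound 4 in this assay the expected value is 60%, within a range from 25% to 90%.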

Compound 4, a percentage reported as inhibition, at one concentration (the size of the read-out at that concentration, not a potency): 0%
For compound 4 the middle estimate is 60 percentage points above the measured one; the whole stated range lies above it.
By their numbers in this assay, from the lowest: compound 4; then compound 3; then compounds 2 and 1 (each within the scatter of the next).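

In this assay, ethyl in place of 2-methoxy-5-methylphenyl on the ring nitrogen gives a number 92 percentage points lower from compound 2 to compound 4 (beyond the scatter), and compound 4, at 0%, shows no inhibition at the concentration tested. Going by these compounds alone, all the earlier compounds carried an aryl group on this nitrogen, so they could not show what happens without one: this single change shows that the remainder of compound 2, kept intact in compound 4, is not enough to give inhibition in this assay when ethyl occupies this position. No measurement is available that would explain the loss, so the result records its size but not its cause.

The compounds shown leave open whether the aromatic ring itself is needed or whether a larger non-aromatic group on this nitrogen, such as cyclohexyl or a longer chain such as n-butyl, would restore inhibition, and where benzyl or an unsubstituted phenyl would fall between these cases. They also leave open whether ethyl would have the same effect on the cores of compound 1 and compound 3.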